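Decyl-to-hydrogen step on the triazole of compound 2

The compounds below may be only part of what the source reports. "The series", "measured", "known", "first", "only" and "open" are said of these compounds alone.

Working notes on the series. Compound 1 `O=C1O/C(=C\Cn2cc(-c3cc(F)cc(F)c3)nn2)C(OCc2ccccc2)=C1OCc1ccccc1` is tested in a functional assay on HepG2 cells (Homo sapiens) for antiproliferative activity, read by MTT assay, with a stated time of 72 h; a lower number here means a stronger inhibitor, a higher number a weaker inhibitor. In this assay compound 1 gives only a limit, > 100000 nM, and no number. Within the data shown here, compound 2 `CCCCCCCCCCc1cn(C[C@H](O)[C@H]2OC(=O)C(OCc3ccccc3)=C2OCc2ccccc2)nn1` is the one compound with a number here: in this assay compound 2 gives 12200 nM. Within the shown values compound 2 therefore stands as the only measured point, with the other value being a limit (the limit of > 100000 nM in this assay, at which 1 of the 2 values shown sits). Compound 3 `O=C1O[C@H]([C@@H](O)Cn2ccnn2)C(OCc2ccccc2)=C1OCc1ccccc1` is not yet measured in this assay. Compound 3 differs from compound 2 by hydrogen in place of decyl on an aromatic carbon. Among the measured compounds shown here, no step between measured compounds is available, so the size of this change is not anchored by data. For the measured compounds named here, the expected step is a loss of potency, a 4.9-fold higher number from compound 2 to compound 3 (0.69 log units; beyond the scatter), since the decyl group is the one sizeable difference from compound 2 at that ring carbon. For compound 3 the estimated value in this assay is 60000 nM, expected to lie between 15000 nM and 200000 nM, with a real chance that only a limit is returned.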

Compound 3, half-maximal inhibitory concentration: > 100000 nM
Compound 3 was reported as a limit (the forecaster's own chance of this, stated with the estimate: 45%); middle value at least 1.6-fold (0.22 log units) from the limit.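

Replacing decyl by hydrogen at this aromatic carbon gives the first measured size for this change, an at least 8.1-fold higher number from compound 2 to compound 3 (0.91 log units; beyond the scatter), so the measurable activity of compound 2 in this assay is tied to what this ring carbon carries. Going by these compounds, the step is only a lower bound, and its true size remains unknown. Compound 3 gives a limit and not a number, and limits now make up most of the values shown: the limit of > 100000 nM in this assay, at which 2 of the 3 values shown sit.

A single pair cannot show whether decyl itself is needed or whether a shorter chain such as hexyl, a longer chain such as dodecyl, or a phenyl ring at this carbon would serve as well. On these data alone, it also remains open whether a chain ending in an amine or a carboxylic acid would retain the value of compound 2.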